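A few compounds are considered here, and "the series" means these few. Any claim that something is new, unique, unknown or untested is made for them only; others in the source may bear on it.

For the measured compounds named here, in an assay on isolated protein for activation of cGMP-dependent protein kinase 1 (Homo sapiens), read by ADP-Glo, with stated times of 120 min and 40 min (on this read-out higher numbers stand for an effect only at larger amounts of compound and lower numbers for an effect already at smaller amounts), compound 1 `OC[C@@H](O[C@H]1CCCN(Cc2ccccc2Cc2nnco2)[C@H]1c1ccccc1)c1cc(Cl)cc(Cl)c1` gives 3700 nM and compound 3 `OC[C@@H](O[C@H]1CCCN(Cc2cccc3nonc23)[C@H]1c1ccccc1)c1cc(Cl)cc(Cl)c1` gives 8000 nM; the step of a 2.2-fold higher number from compound 1 to compound 3 (0.33 log units; beyond the scatter) is the only measured change at the same place as the one considered here. Compound 2 `Clc1cc(Cl)cc(CO[C@H]2CCCN(Cc3ccccn3)[C@H]2c2ccccc2)c1` reaches only the assay limit, > 200000 nM, a limit rather than a number, as the limit of > 200000 nM in this assay, at which 1 of the 3 values shown sits, records. Compound 4 `CN1CCC[C@H](OCc2cc(Cl)cc(Cl)c2)[C@@H]1c1ccccc1` differs from compound 2 by hydrogen in place of pyridin-2-yl on a saturated chain carbon bound to an amine nitrogen in a ring. Going by the values given here, no measured step removes a whole aromatic group from that carbon, so the size of this change cannot be read from the series; compound 2 already stands at the limit, and nothing measured points to a move into numbered values. Compound 4 is therefore expected to remain at the limit, estimated as 300000 nM with a range of 100000 nM to 1000000 nM. The expected step is a step that the limit leaves unreadable from compound 2 to compound 4.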

Compound 4, half-maximal effective concentration: > 200000 nM
Compound 4: a limit, no number; the forecaster's own chance of this, stated with the estimate: 80%; the middle value lies beyond the limit too.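

Compound 2 and compound 4 both stand as limits, not numbers, in this assay, so no step can be read between them. As far as these compounds go, what the replacement of pyridin-2-yl by hydrogen does to the read-out stays open.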